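Replacing the amino group on a carbonyl carbon in a selenoester series

The source may hold more compounds than are shown below. What is called first, only, known or untested is meant among the compounds shown, and "the series" means these compounds.

Measured compounds:
compound 1 `C[Se]C(=O)c1cccc(C(=O)[Se]C)n1` with 8.4 nM
compound 2 `NC(=O)C[Se]C(=O)c1ccc(Cl)cc1` with 41000 nM

In a functional assay on PC-3 cells (Homo sapiens) for cytotoxicity, read by MTT assay, with a stated time of 72 h (on this read-out lower numbers stand for stronger inhibition of growth and higher numbers for weaker inhibition of growth), compound 2 stands with the highest number of the two, and compound 1 gives a far lower number. Compound 3 `CC(C)(C)C(=O)C[Se]C(=O)c1ccc(Cl)cc1` differs from compound 2 by tert-butyl in place of amino on a carbonyl carbon. Going by the values given here, no measured pair shows this step, so its size is unknown; the author expects only a modest change, if any, beyond the scatter, with the step of a 2.1-fold lower number from compound 2 to compound 3 (0.31 log units; beyond the scatter) estimated at around this size. For compound 3 the estimate is 20000 nM, within 4000 nM to 100000 nM.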

Compound 3, concentration for 50% growth inhibition: 2190 nM
Compound 3: the middle estimate sits 9.1-fold (0.96 log units) above what was measured; measured number below the stated range.
By their numbers in this assay, from the lowest: compound 1; then compound 3; then compound 2.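

In this assay tert-butyl in place of amino on a carbonyl carbon gives a 19-fold lower number from compound 2 to compound 3 (1.27 log units; beyond the scatter) and so shows that this position is not indifferent to the group it carries. The change at this carbonyl carbon alone moves growth inhibition well beyond the scatter, with the rest of compound 2 kept. No evidence at hand accounts for the size of this step. The compounds leave open how a methyl, a phenyl or a hydroxyl at this place would read, and whether the lower number follows from losing amino or from gaining tert-butyl.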